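Shifting a cyclic amine from pyrrolidine to piperidine

The compounds below may be only part of what the source reports. "The series", "measured", "known", "first", "only" and "open" are said of these compounds alone.

Three compounds share one core and differ only in the amine-bearing chain on the amide nitrogen. Compound 1 `Cc1ccc2[nH]c(C(=O)N[C@H]3CN(S(=O)(=O)c4ccnc(C)c4)C[C@@H]3C(=O)NCCN(C)C)cc2c1` gives 91% in a functional assay on HEK293 cells for agonist activity at growth hormone secretagogue receptor type 1 (Homo sapiens), read by HTRF and inositol phosphate accumulation, with a stated time of 90 min, in the presence of a further agent that is not named here; on this read-out lower numbers stand for smaller maximal responses and higher numbers for larger maximal responses. Compound 2 `Cc1ccc2[nH]c(C(=O)N[C@H]3CN(S(=O)(=O)c4ccccc4)C[C@@H]3C(=O)NC[C@H]3CCCN3)cc2c1` gives 94% in this assay. Compound 3 `Cc1ccc2[nH]c(C(=O)N[C@H]3CN(S(=O)(=O)c4ccccc4)C[C@@H]3C(=O)NC[C@@H]3CCCN3C)cc2c1` gives 87% in this assay; its gaps to compound 1 and to compound 2 are both within the usual scatter, so the three cannot be ranked against one another.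

Within the data shown here, the only measured step touching this region is a number 7 percentage points lower from compound 2 to compound 3 (within the scatter), which adds a methyl on the pyrrolidine nitrogen and leaves the maximal response unchanged beyond the scatter.

Compound 4 `Cc1ccc2[nH]c(C(=O)N[C@H]3CN(S(=O)(=O)c4ccccc4)C[C@@H]3C(=O)N[C@@H]3CCCN(C)C3)cc2c1` is built from compound 3 by the change (1-methylpiperidin-3-yl in place of (1-methylpyrrolidin-2-yl)methyl on an amide-type nitrogen). Among the measured compounds shown here, no measured pair shows exactly this ring rearrangement, so the expectation rests on the observation that the one nearby change, a number 7 percentage points lower from compound 2 to compound 3 (within the scatter), did not move the read-out beyond the scatter. The step is therefore expected to be a number 1 percentage points higher from compound 3 to compound 4 (within the scatter), with no change beyond the scatter. Compound 4 is estimated to give 88% in this assay, in a range from 78% to 98%.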

Compound 4, largest response reached (Emax), in percent of the reference or control that the assay uses: 91%
The estimate for compound 4 lay 3 percentage points below the measured number, within the range that was stated.
By their numbers in this assay, from the lowest: compounds 3, 1, 4 and 2 (each within the scatter of the next).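

In this assay, replacing (1-methylpyrrolidin-2-yl)methyl with 1-methylpiperidin-3-yl on the amide-type nitrogen gives a number 4 percentage points higher from compound 3 to compound 4 (within the scatter), so the same atoms joined differently, now as a six-membered ring instead of a five-membered one, keep the maximal response within the scatter. The comparison with the unmethylated ring points the same way, with a number 3 percentage points lower from compound 2 to compound 4 (within the scatter), so across compounds 2, 3 and 4 neither ring size, nor the way the ring is attached, nor the methyl on its nitrogen has moved the maximal response beyond the scatter. Nothing available here offers an explanation for this steady response.

The compounds shown leave open whether the response would hold with a carboxylic acid or a plain cyclohexyl group at this position, neither of which carries an amine. They also leave open how piperidin-3-yl without the methyl, the opposite stereoisomer of 1-methylpiperidin-3-yl, or a longer chain carrying the piperidine ring would behave.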